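The compounds below may be only part of what the source reports. "The series", "measured", "known", "first", "only" and "open" are said of these compounds alone.

Measured so far:
compound 1 `NCCn1ncc2c(NCc3ccccc3[N+](=O)[O-])cc(C(F)(F)F)cc21` — in an assay for inhibition of Tryptophan 2,3-dioxygenase (Homo sapiens), with stated times of 10 min and 60 min (a lower number here means a stronger inhibitor, a higher number a weaker inhibitor), compound 1 gives > 100000 nM, a limit of the assay rather than a number.
compound 2 `O=C(O)CNc1cccc(CNc2cc(C(F)(F)F)cc3[nH]ncc23)c1` — compound 2 gives > 100000 nM, again a limit and not a number.
compound 3 `FC(F)(F)c1cc(NC[C@@H]2CCCCN2)c2cn[nH]c2c1` — compound 3 gives 8050 nM.

Compound 2 therefore stands at the edge of what this assay can report, at the limit of > 100000 nM in this assay, at which 2 of the 3 values shown sit. Compound 4 `CNC(=O)c1cccc(CNc2cc(C(F)(F)F)cc3[nH]ncc23)c1` differs from compound 2 in a single place: methylcarbamoyl in place of (carboxymethyl)amino on an aromatic carbon. Among the measured compounds shown here, no pair of measured compounds differs in just one place, so there is no measured step to gauge this change against, and only compound 3, with a different side group, reaches a readable value. The step of an at least 1.6-fold lower number from compound 2 to compound 4 (0.22 log units; that floor lies within the scatter) is expected to amount to nothing beyond the scatter of this assay. The estimate for compound 4 is 60000 nM, with a range from 10000 nM to 300000 nM.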

Compound 4, half-maximal inhibitory concentration: 4870 nM
Beside the measured number, compound 4's estimate is 12-fold (1.09 log units) above it; the measured number lies below the stated range.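

On this aromatic carbon, the choice of side group matters: in this assay, methylcarbamoyl in place of (carboxymethyl)amino gives an at least 20-fold lower number from compound 2 to compound 4 (1.31 log units; beyond the scatter). This first measured step turns a compound with no readable value into one with a readable value. The step is only a floor, and its full size stays unknown, since compound 2 gives a limit and not a number: the limit of > 100000 nM in this assay, at which 2 of the 4 values shown sit.

Still open, as far as these compounds go, is whether a primary amide or a nitrile on the same carbon would give a similar drop. So is whether a longer chain on the amide nitrogen would keep it.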